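This account rests on a few compounds, and the source may have more. Where it says the series, first, only, none or still open, it means among the compounds named here.

Measured so far:
Compound 1, `c1ccc(CN[C@H]2CC[C@@H](c3c[nH]c4ccccc43)CC2)cc1`: in an assay on cell membranes for binding affinity to Adrenergic receptor alpha-1 (Rattus norvegicus), tested at 1 uM (a lower number here means less inhibition, a higher number more inhibition at the concentration tested (going by the name of the read-out)), compound 1 gives 21%.
Compound 2, `N#Cc1ccc2[nH]cc([C@H]3CC[C@@H](NCc4ccccc4)CC3)c2c1`: in this assay compound 2 gives 17%.

Compound 2 sits at 17% against compound 1 at 21%; the step of a number 4 percentage points lower from compound 1 to compound 2 (within the scatter) lies within the scatter, so the two numbers cannot be told apart on the data shown.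

Compound 3, `Fc1ccc2[nH]cc([C@H]3CC[C@@H](NCc4ccccc4)CC3)c2c1`, differs from compound 2 by fluoro in place of cyano on an aromatic carbon. Going by the values given here, the only measured step that touches this position is a number 4 percentage points lower from compound 1 to compound 2 (within the scatter), where cyano entered in place of hydrogen and the read-out hardly moved. With fluoro now replacing cyano at the same aromatic carbon, and nothing else in the series pointing to a larger effect, the expectation is a step of a number 1 percentage points higher from compound 2 to compound 3 (within the scatter) from compound 2 to compound 3, none beyond the scatter. Compound 3 is therefore estimated at 18% in this assay, with a range from 6% to 31%.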

Compound 3, a percentage reported as inhibition, at one concentration (the size of the read-out at that concentration, not a potency): 9%
Compound 3: middle estimate off by 9 percentage points, on the high side, within the range that was stated.
By their numbers in this assay, from the lowest: compounds 3, 2 and 1 (each within the scatter of the next, the first and the last beyond it).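

In this assay, going by these compounds alone, fluoro gives the first step at this aromatic carbon that lies beyond the scatter: with fluoro in place of hydrogen, the read-out is a number 12 percentage points lower from compound 1 to compound 3 (beyond the scatter). Within the data shown here, the change from cyano to fluoro at the same carbon, a number 8 percentage points lower from compound 2 to compound 3 (within the scatter), does not separate those two compounds, and compound 2 also remains inseparable from compound 1, so only the pair with fluoro and hydrogen is resolved, and only modestly. Nothing available bears on what lies behind this separation.

The compounds shown leave open how a methoxy group or a chlorine at this aromatic carbon would read in this assay. They also leave open whether the modest step with fluoro would persist with a different group on the amine in place of the benzyl group.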